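Series notes: pendant group changes, compounds 1 to 4

This account rests on a few compounds, and the source may have more. Where it says the series, first, only, none or still open, it means among the compounds named here.

In a functional assay on HepG2 cells (Homo sapiens) for cytotoxicity, read by sulforhodamine B assay, with a stated time of 48 h (on this read-out higher numbers stand for weaker inhibition and lower numbers for stronger inhibition), compound 1 `CCOC(=O)c1c(-c2ccc(C)cc2)c(C#N)c(=O)n(/N=C(\C)c2ccc(NS(=O)(=O)c3ccc(Cl)cc3)cc2)c1N` gives 8380 nM, compound 2 `CCOC(=O)c1c(/C=C/c2ccccc2)c(C#N)c(=O)n(/N=C(\C)c2ccc(NS(=O)(=O)c3ccc(Cl)cc3)cc2)c1N` gives 10700 nM and compound 3 `CCOC(=O)c1c(-c2ccc(Cl)cc2)c(C#N)c(=O)n(/N=C(\C)c2ccc(NS(=O)(=O)c3ccc(Cl)cc3)cc2)c1N` gives 20200 nM. Compound 3 holds the highest number of the three: a 1.9-fold higher number from compound 2 to compound 3 (0.28 log units; within the scatter) stays within the scatter, while a 2.4-fold higher number from compound 1 to compound 3 (0.38 log units; beyond the scatter) lies beyond it. Compound 4 `CCOC(=O)c1c(-c2cccc([N+](=O)[O-])c2)c(C#N)c(=O)n(/N=C(\C)c2ccc(NS(=O)(=O)c3ccc(Cl)cc3)cc2)c1N` carries 3-nitrophenyl in place of 4-chlorophenyl on an aromatic carbon. Both measured steps ending at compound 3 bear on this change; each of them also exchanges the group on an aromatic carbon, and the shifts seen were modest at most. A step of a 1.3-fold lower number from compound 3 to compound 4 (0.13 log units; within the scatter) is therefore expected, with no firm direction. Compound 4 is estimated at 15000 nM in this assay, within the range 6000 nM to 40000 nM.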

Compound 4, half-maximal inhibitory concentration: 29700 nM
Beside the measured number, compound 4's estimate is 2.0-fold (0.30 log units) below it; measured number inside the range.
By their numbers in this assay, from the lowest: compounds 1, 2, 3 and 4 (each within the scatter of the next, the first and the last beyond it).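

In this assay the 3-nitrophenyl group at this position reads with the 4-chlorophenyl group, a 1.5-fold higher number from compound 3 to compound 4 (0.17 log units; within the scatter) staying within the scatter, but apart from the other two pendants, with a 2.8-fold higher number from compound 2 to compound 4 (0.44 log units; beyond the scatter) and a 3.5-fold higher number from compound 1 to compound 4 (0.55 log units; beyond the scatter) both beyond it. The first pendant here with hydrogen-bond acceptors thus sits at the high end of the series, though these steps remain modest. No measurement shown accounts for these shifts.

Open, going by these compounds, is how a phenyl ring carrying an amine or a carboxylic acid would read at this position. Also open, on these data alone, is how a longer alkyl chain, with no ring, would compare.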